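Methoxy in Place of Hydrogen on Compound 2

This account rests on a few compounds, and the source may have more. Where it says the series, first, only, none or still open, it means among the compounds named here.

Compound 1 `O=C(N/N=C/c1cccc(O)c1)c1cccnc1Nc1cccc(C(F)(F)F)c1`: 65.4%
Compound 2 `CNc1ncccc1C(=O)N/N=C/c1ccccc1`: 47.2%
Compound 3 `CNc1ncccc1C(=O)N/N=C/c1ccc(Cl)cc1`: 54.1%

Of the compounds shown here, three have been tested in a functional assay on the whole organism (strain Wistar) for inhibition, with Rattus norvegicus as the target, read by paw edema, with a stated time of 2 h, at a dose of 10 mg/kg by the intraperitoneal route; a higher number here means more inhibition at the dose given (going by the name of the read-out), a lower number less inhibition. Among them compound 2 gives the lowest number, 47.2%. Its nearest neighbour is compound 3, whose number lies higher but within the scatter; compound 1, with 65.4%, lies furthest away, beyond the scatter.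

The next compound, compound 4 `CNc1ncccc1C(=O)N/N=C/c1cccc(OC)c1`, keeps the whole of compound 2 and changes it in a single place: methoxy in place of hydrogen on an aromatic carbon.

Within the data shown here, only one measured step bears on this change. Going a number 6.9 percentage points higher from compound 2 to compound 3 (within the scatter), where the only change is an added chloro group, the number moved by an amount the assay cannot distinguish from repetition. Compound 1 carries a hydroxy group on the same kind of ring, but it also differs from compound 2 in a second place, so the number for compound 1, 65.4%, can only be noted, not traced to the ring substituent alone.

On this basis no step beyond the scatter is expected in this assay ; compound 4 is estimated to move by a number 4.8 percentage points higher from compound 2 to compound 4 (within the scatter). The expected value for compound 4 is 52%, within a range from 40% to 64%.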

Compound 4, a percentage reported as inhibition, in the whole organism at one dose (the size of the read-out at that dose, not a potency): 51.5%
Compound 4: the middle estimate sits 0.5 percentage points above what was measured, within the range that was stated.
By their numbers in this assay, from the lowest: compounds 2, 4 and 3 (each within the scatter of the next); then compound 1.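

In this assay, methoxy on an aromatic carbon meta to a large group gives a number 4.3 percentage points higher from compound 2 to compound 4 (within the scatter) and so cannot be told apart from repeating the measurement. Read with a number 6.9 percentage points higher from compound 2 to compound 3 (within the scatter) as a second single change on the same ring of compound 2, this shows that neither methoxy nor chloro produces a step beyond the scatter, although the two groups differ in their atoms and methoxy brings a hydrogen-bond acceptor. No measurement of another kind is available to explain this result.

The compounds shown leave open whether a different group at this place, such as an amine, a carboxylic acid or a longer chain like butoxy, would produce a step beyond the scatter. They also leave open what lies behind the number of compound 1, 65.4%, since compound 1 differs from compound 2 in more than one place and its step from compound 2 cannot be read as the effect of any single change.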